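Two Benzylamine Sulfonamides and an Untested Bromophenyl Analogue

This account rests on a few compounds, and the source may have more. Where it says the series, first, only, none or still open, it means among the compounds named here.

The series rests on a shared bis(trifluoromethyl)phenylsulfonamide core carrying an aminoalkyl chain that ends in a substituted benzyl group. In a functional assay on ASPC1 cells (Homo sapiens) for inhibition, read by MTT assay, with a stated time of 72 h (on this read-out higher numbers stand for weaker inhibition of growth and lower numbers for stronger inhibition of growth), compound 1 `O=S(=O)(NCCNCc1cccc2ccccc12)c1cc(C(F)(F)F)cc(C(F)(F)F)c1` gives 22000 nM. Compound 2 `O=S(=O)(NCCCNCc1ccc(Cl)c(Cl)c1)c1cc(C(F)(F)F)cc(C(F)(F)F)c1`, which carries a three-carbon chain and a 3,4-dichlorobenzyl group, gives 2800 nM in this assay and so stands as the lower of the two numbers measured, with the gap to compound 1 lying beyond the scatter; the two differ in more than one place, so nothing finer is drawn from them.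

Compound 3 `O=S(=O)(NCCCNCc1ccc(Br)cc1)c1cc(C(F)(F)F)cc(C(F)(F)F)c1` has not yet been measured. Relative to compound 2 it carries 4-bromophenyl in place of 3,4-dichlorophenyl on a saturated chain carbon bound to an amine nitrogen, with the chain and the core left untouched. Going by the values given here, no measured pair isolates this change, so the expectation for compound 3 in this assay is worded loosely: a modest weakening seems plausible, and the step of a 1.8-fold higher number from compound 2 to compound 3 (0.25 log units; within the scatter) is expected to be small, perhaps within the scatter. Compound 3 is estimated at 5000 nM, with a range from 1500 nM to 16000 nM.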

Compound 3, concentration for 50% growth inhibition: 2800 nM
For compound 3 the middle estimate is 1.8-fold (0.25 log units) above the measured one; low and high end bracket the measured number.
By their numbers in this assay, from the lowest: compounds 2 and 3 (each within the scatter of the next); then compound 1.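

In this assay, going by these compounds alone, putting 4-bromophenyl in place of 3,4-dichlorophenyl on a saturated chain carbon bound to an amine nitrogen gives no change at the digits printed from compound 2 to compound 3 (within the scatter), and this is the only step in the set that isolates a single change. At this position, a group of 7 heavy atoms carrying 1 bromine therefore stands in for a group of 8 heavy atoms carrying 2 chlorine, with no difference that this read-out can separate from the scatter. Nothing measured on these compounds accounts for this result, which stands here without an explanation.

Compound 1 differs from compound 2 and from compound 3 in more than one place, so its steps cannot be read, and the contributions of chain length and the group at the end of the chain remain unseparated. Going by these compounds, it also remains open how this position would respond to a plain benzyl group, a 4-chlorobenzyl group or a 4-methoxybenzyl group, or how the shared core would respond to a longer chain with the 4-bromobenzyl group kept in place.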